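The source may hold more compounds than are shown below. What is called first, only, known or untested is meant among the compounds shown, and "the series" means these compounds.

Values measured in a functional assay on HT-1080 cells (Homo sapiens), read by luminescence, with a stated time of 24 h; a lower number here means that less compound is needed, a higher number that more compound is needed for the effect:

- Compound 1 `CC1(C)CC(NC(=O)C(C)(C)/C=C/[C@H](NC(=O)OC(C)(C)C)c2ccccc2)CC(C)(C)N1`: 330 nM
- Compound 2 `CC1(C)CC(NC(=O)C(/C=C/[C@@H](NC(=O)OC(C)(C)C)c2ccc(F)cc2)(Cc2ccc(F)cn2)Cc2ccc(F)cn2)CC(C)(C)N1`: > 2000 nM, a limit of the assay and not a number
- Compound 3 `CC(C)C[C@@H](/C=C/C(C)(C)C(=O)NC1CC(C)(C)NC(C)(C)C1)NC(=O)OC(C)(C)C`: 240 nM

Only two of these results are numbers. Compound 3 at 240 nM and compound 1 at 330 nM lie within the scatter of each other, so neither can be ranked above the other.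

The next compound to be tested is compound 4 `CC(C)C[C@H](/C=C/C(C)(C)C(=O)NC1CC(C)(C)NC(C)(C)C1)NC(=O)OC(C)(C)C`. Its relation to compound 3 is the two compounds have the same atoms and bonds and differ only in configuration as drawn: 1 of 2 stereo elements differ; a stereocentre at a saturated chain carbon is drawn S in compound 3 and R in compound 4; a stereocentre at a saturated chain carbon is drawn S in compound 3 and R in compound 4. Among the compounds with values here, no measured pair shows what a change of configuration does in this assay, so the expectation is loose. No shift beyond the scatter is expected, although a small move towards a higher number remains possible. The expected step of a 1.2-fold higher number from compound 3 to compound 4 (0.08 log units; within the scatter) is no larger than the scatter. For compound 4 the estimated value is 290 nM, with an expected range from 120 nM to 800 nM.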

Compound 4, half-maximal effective concentration in the HT-1080 assay: 250 nM
For compound 4 the middle estimate is 1.2-fold (0.06 log units) above the measured one; measured number inside the range.
By their numbers in the HT-1080 assay, from the lowest: compounds 3, 4 and 1 (each within the scatter of the next). At a limit, above all of these: compound 2.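

Within the data shown here, in the HT-1080 assay the pair gives the first reading of configuration at this saturated chain carbon, and the step is a 1.0-fold higher number from compound 3 to compound 4 (0.02 log units; within the scatter), while in a physicochemical assay for lipophilicity (a higher number here means a more lipophilic compound, a lower number a more polar compound), the step is no change at the digits printed from compound 3 to compound 4 (within the scatter). In the physicochemical assay compound 3 gives 4 and compound 4 gives 4. With isobutyl in place of phenyl on this carbon, the HT-1080 assay also shows no shift beyond the scatter, with a 1.3-fold lower number from compound 1 to compound 4 (0.12 log units; within the scatter). The first of these comparisons reads configuration alone, with no other change in the structure: the fact that compounds 3 and 4 differ only in the configuration as drawn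

Among these compounds, it stays open whether configuration at this carbon would matter as little with phenyl on it, since the only pair that reads configuration carries isobutyl. The compounds shown also leave open what a longer chain, an amine or a carboxylic acid in place of isobutyl would do in the HT-1080 assay.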